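The source may report more compounds than this note shows. Statements on the series, on what has been measured and on what is new or still open speak of the compounds shown alone.

Measured compounds:

compound 1 `O=C1CCCCN1[C@@H]1c2cc([N+](=O)[O-])ccc2OC(CF)(CF)[C@H]1O`: 2.75 nM
compound 2 `O=C1CCCCN1[C@@H]1c2cc(C(F)(F)C(F)(F)F)ccc2OC(CF)(CF)[C@H]1O`: 3.89 nM
compound 3 `O=c1ccccn1C1=CC(CF)(CF)Oc2ccc([N+](=O)[O-])cc21`: 2.46 nM

All three values come from a functional assay (aorta) with Rattus norvegicus as the target; on this read-out lower numbers stand for an effect already at smaller amounts and higher numbers for an effect only at larger amounts of compound. Compound 1 and compound 2 share one core and differ in a single place; the step of a 1.4-fold higher number from compound 1 to compound 2 (0.15 log units; within the scatter) belongs to the change (1,1,2,2,2-pentafluoroethyl in place of nitro on an aromatic carbon). Compound 3 carries a different core; the difference between the two cores is not broken down here, and what the two values show is that compound 3 and compound 1 sit within the scatter of each other in this assay.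

Compound 4 `O=c1ccccn1C1=CC(CF)(CF)Oc2ccc(C(F)(F)C(F)(F)F)cc21` is not yet measured. It stands to compound 3 as compound 2 stands to compound 1: the change is 1,1,2,2,2-pentafluoroethyl in place of nitro on an aromatic carbon, the same change as before, at the same kind of place. For the measured compounds named here, the only measured instance of this change is the step from compound 1 to compound 2, which lies within the scatter. On that footing the step from compound 3 to compound 4 is expected to be about a 1.4-fold higher number from compound 3 to compound 4 (0.15 log units; within the scatter), resting on a 1.4-fold higher number from compound 1 to compound 2 (0.15 log units; within the scatter). For compound 4 the estimated value in this assay is 3.5 nM, with a range from 1.5 nM to 8 nM.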

Compound 4, half-maximal effective concentration: 2.95 nM
The estimate for compound 4 lay 1.2-fold (0.07 log units) above the measured number, and the stated range covers the measured number.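

In this assay, 1,1,2,2,2-pentafluoroethyl in place of nitro on an aromatic carbon gives a 1.2-fold higher number from compound 3 to compound 4 (0.08 log units; within the scatter), and set beside the earlier step it reads: the same change on two cores in this assay, a 1.4-fold higher number (0.15 log units; within the scatter) from compound 1 to compound 2 and a 1.2-fold higher number (0.08 log units; within the scatter) from compound 3 to compound 4, 1.2-fold (0.07 log units) apart, within the scatter of two such steps. On these two cores, the change therefore carries over consistently, and on neither core does the swap move the number beyond the scatter. For the compounds shown here, this is agreement between two small steps, so it shows only that the two groups can be exchanged at this place on these two cores in this one read-out; it does not show that a step of real size would transfer between cores, nor that the two groups are equivalent in any other respect.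

Still open, from the compounds shown here alone, is how an amine, a carboxylic acid or a longer fluorinated chain on that aromatic carbon would behave on either core, and whether any group there would shift the number beyond the scatter. Also open, going by these compounds, is whether the agreement would hold on a third core or in a read-out other than this assay.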